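A few compounds are considered here, and "the series" means these few. Any claim that something is new, unique, unknown or untested is made for them only; others in the source may bear on it.

Working notes on the acyl series. Compound 1 `CC(=O)N1CCc2nc(C#Cc3ccccc3)sc2C1` carries methyl on the carbonyl carbon, and in an assay on HEK293 cells for negative allosteric modulation of metabotropic glutamate receptor 5 (Homo sapiens), read by FLIPR, with a stated time of 1 h (on this read-out higher numbers stand for weaker inhibition and lower numbers for stronger inhibition), compound 1 gives 90 nM. Compound 2 `COC1CC(C(=O)N2CCc3nc(C#Cc4ccccc4)sc3C2)C1` carries 3-methoxycyclobutyl there and reaches only a limit of this assay: compound 2 gives > 10000 nM. Compound 3 `O=C(c1cccc(Cl)c1)N1CCc2nc(C#Cc3ccccc3)sc2C1` carries 3-chlorophenyl there and likewise stops at a limit: compound 3 gives > 10000 nM. Compound 3 thus stands at the limit of > 10000 nM in this assay, at which 2 of the 3 values shown sit, so its position is known only as that limit. The measured steps run an at least 110-fold higher number from compound 1 to compound 2 (2.04 log units; beyond the scatter) and an at least 110-fold higher number from compound 1 to compound 3 (2.04 log units; beyond the scatter); the third pair is unreadable: a step that the two limits leave unreadable from compound 2 to compound 3.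

Compound 4 `Cc1nc(C(=O)N2CCc3nc(C#Cc4ccccc4)sc3C2)cs1` is reached from compound 3 by 2-methyl-1,3-thiazol-4-yl in place of 3-chlorophenyl on a carbonyl carbon. Among the compounds with values here, the steps that bear on it are the two from methyl to a ring on the carbonyl carbon, both large and both ending at the limit; no measured step separates two ring-bearing groups at that position. The change to compound 4 keeps a ring of similar size on the carbonyl carbon, so compound 4 is expected to remain close to the limit, with an at least 1.2-fold lower number from compound 3 to compound 4 (0.09 log units; that floor lies within the scatter) expected to stay within the scatter or be unreadable. The estimate for compound 4 in this assay is 8000 nM, with a range of 1500 nM to 30000 nM.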

Compound 4, half-maximal inhibitory concentration: > 10000 nM
Compound 4: only a limit was reported; the forecaster's own chance of this, stated with the estimate: 60%; middle value at least 1.2-fold (0.09 log units) from the limit.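

The step from methyl to 2-methyl-1,3-thiazol-4-yl on the carbonyl carbon is again large in this assay, an at least 110-fold higher number from compound 1 to compound 4 (2.04 log units; beyond the scatter), so a five-membered aromatic ring with 2 hetero atoms and 2 hydrogen-bond acceptors also fails to bring the value back within the range of the assay. The steps among compound 2, compound 3 and compound 4 cannot be read, since each of the three values is a limit, and no order among these groups follows. The acyl series now rests mostly on limits, not on numbers: the limit of > 10000 nM in this assay, at which 3 of the 4 values shown sit.

On these data alone, how far compound 2, compound 3 and compound 4 lie past the limit remains open. Also open, as far as these compounds go, is whether ethyl, cyclopropyl or a dimethylamino group on the carbonyl carbon would keep a value close to compound 1 at 90 nM.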